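The compounds below may be only part of what the source reports. "The series", "measured", "known", "first", "only" and "open" are said of these compounds alone.

Measured compounds:
- Compound 1, `CCn1c(CNc2ccccc2)nnc1SCC(=O)Nc1ccc(C(=O)OC)cc1`: in an assay on isolated protein for inhibition of long-chain fatty acid transport protein 1 (Mus musculus) (a higher number here means a weaker inhibitor, a lower number a stronger inhibitor), compound 1 gives "not determined" (no result reported).
- Compound 2, `CCn1c(CNc2ccccc2)nnc1SCc1nc2cc(F)ccc2o1`: compound 2 gives 7800 nM.
- Compound 3, `CC/C(=N/OC)c1ccc2oc(CSc3nnc(CNc4ccccc4)n3CC)nc2c1`: compound 3 gives > 10000 nM, which is a limit of the assay and not a number (the limit of > 10000 nM in this assay, at which 1 of the 3 values shown sits).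

Compound 1 therefore stands nowhere on the numbers: no value exists for it in this assay. The change to compound 4, `CCn1c(CNc2ccccc2)nnc1SCC(=O)Nc1ccc(C(=O)OC(C)(C)C)cc1`, is tert-butyl in place of methyl on an oxygen next to a carbonyl group. Among the compounds with values here, the only measured step, an at least 1.2-fold higher number from compound 2 to compound 3 (0.10 log units; that floor lies within the scatter), concerns a different part of the shared core and stays within the scatter, so it offers no guidance on the size or direction of the methyl to tert-butyl step. With the measured compounds weak and one resting at the limit, compound 4 is expected to give about 9000 nM in this assay, with a range from 2500 nM to 30000 nM.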

Compound 4, half-maximal inhibitory concentration: > 10000 nM
Compound 4: no number, only a limit; the forecaster's own chance of this, stated with the estimate: 45%; middle value at least 1.1-fold (0.04 log units) away from the limit.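

In this assay compound 4 gives > 10000 nM, which is a limit of the assay. Within the data shown here, compound 1 has no number to set against it, so no step between compound 1 and compound 4 can be read. The compounds shown leave open what methoxycarbonyl to tert-butoxycarbonyl does to inhibition.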